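The source may report more compounds than this note shows. Statements on the series, on what has been measured and on what is new or still open speak of the compounds shown alone.

Compound 1, `C#Cc1cn([C@@H]2O[C@H](CO)[C@@H](O)[C@H]2O)c2ncnc(C)c12`, carries an ethynyl group on the five-membered aromatic ring of the shared core together with a methyl group elsewhere on that core. In a functional assay on HCT-116 cells (Homo sapiens), read by MTT assay, with a stated time of 72 h (a lower number here means a stronger inhibitor, a higher number a weaker inhibitor), compound 1 gives only a limit, > 20000 nM, so no number is known for it. Compound 2, `COc1ncnc2c1c(-c1cccs1)cn2[C@@H]1O[C@H](CO)[C@@H](O)[C@H]1O`, carries a thiophen-2-yl group at the same place on the five-membered ring and a methoxy group instead of the methyl. Among the measured compounds shown here, compound 2 gives 80 nM in this assay, the only real number among the two values shown. The value of compound 1 is a limit, as the limit of > 20000 nM in this assay, at which 1 of the 2 values shown sits, records. Compound 3, `C#Cc1cn([C@@H]2O[C@H](CO)[C@@H](O)[C@H]2O)c2ncnc(OC)c12`, has not been measured; it keeps the methoxy group of compound 2 and differs from it in one place: ethynyl in place of thiophen-2-yl on an aromatic carbon. Compound 1 shows that an ethynyl group at that place, alongside a methyl group, gives no measurable number. For compound 3 a marked loss of potency is therefore expected, a 63-fold higher number from compound 2 to compound 3 (1.80 log units; beyond the scatter), though nothing shows how much of the potency of compound 2 rests on the thiophen-2-yl group alone. Compound 3 is estimated at 5000 nM, within a range from 800 nM to 20000 nM, and the assay may again report only a limit.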

Compound 3, half-maximal inhibitory concentration: 4060 nM
Compound 3: middle estimate off by 1.2-fold (0.09 log units), on the high side; the measured number falls inside the stated range.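

In this assay, among the compounds shown here, with the methoxy group held fixed, ethynyl in place of thiophen-2-yl on this aromatic carbon gives a 51-fold higher number from compound 2 to compound 3 (1.71 log units; beyond the scatter); this is the first comparison that separates the group at this place from the rest of the molecule, since compound 1 and compound 2 differ in two places. With the ethynyl group held fixed, methoxy in place of methyl gives an at least 4.9-fold lower number from compound 1 to compound 3 (0.69 log units; beyond the scatter), so the group at the second place also changes the result, and the ethynyl compound can give a real number when methoxy is present. The size of that second step remains open-ended, as compound 1 gives only a limit and not a number: the limit of > 20000 nM in this assay, at which 1 of the 3 values shown sits.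

With only ethynyl and thiophen-2-yl to compare at this place, the compounds shown do not tell whether a ring as such is what goes with the lower number, or how a phenyl ring, a furan-2-yl group or a simple ethyl chain would compare. They also leave open how a compound with thiophen-2-yl and methyl, or with an amine in place of the methoxy group, would behave.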